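Two bromophenyl compounds and a 3-hydroxyphenyl question

This account rests on a few compounds, and the source may have more. Where it says the series, first, only, none or still open, it means among the compounds named here.

Compound 1 `COc1cccc(/C=C2\CCC/C(=C\c3ccccc3Br)C2=O)c1OC`: 12100 nM
Compound 2 `COc1cccc(/C=C2\CCC/C(=C\c3ccc(Br)cc3)C2=O)c1OC`: 11100 nM

Both compounds were measured in a functional assay on SW-620 cells (Homo sapiens) for cytotoxicity, read by MTT assay, with a stated time of 72 h; on this read-out lower numbers stand for stronger inhibition and higher numbers for weaker inhibition. On these numbers compound 2 stands level with compound 1, the two values lying within the scatter of each other. Compound 3 `COc1cccc(/C=C2\CCC/C(=C\c3cccc(O)c3)C2=O)c1OC` has 3-hydroxyphenyl in place of 4-bromophenyl on a double-bonded chain carbon bound to a double-bonded ring carbon. Within the data shown here, only one measured step bears on this change, a 1.1-fold lower number from compound 1 to compound 2 (0.04 log units; within the scatter), and it lies within the scatter. Among the measured compounds shown here, that step exchanged 2-bromophenyl for 4-bromophenyl, and no measured compound carries 3-hydroxyphenyl, so its guidance is weak. For the measured compounds named here, with a 1.1-fold lower number from compound 1 to compound 2 (0.04 log units; within the scatter) as the only guide, no step beyond the scatter is expected in this assay, though with wide uncertainty. The expected change is a 1.2-fold lower number from compound 2 to compound 3 (0.09 log units; within the scatter). For compound 3 the estimated value is 9000 nM, with an expected range of 3500 nM to 22000 nM.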

Compound 3, half-maximal inhibitory concentration: 6400 nM
Estimate against measurement, compound 3: 1.4-fold (0.15 log units) above; low and high end bracket the measured number.
By their numbers in this assay, from the lowest: compounds 3, 2 and 1 (each within the scatter of the next).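

In this assay this position, on a double-bonded chain carbon bound to a double-bonded ring carbon, now has a partner without bromine: 3-hydroxyphenyl, with its hydrogen-bond donor and acceptor, gives a 1.7-fold lower number from compound 2 to compound 3 (0.24 log units; within the scatter) and a 1.9-fold lower number from compound 1 to compound 3 (0.28 log units; within the scatter) in the comparison with the two bromophenyl groups. Neither step leaves the scatter, so compound 1, compound 2 and compound 3 stand level, and exchanging a bromophenyl for a hydroxyphenyl here has not shifted the number measurably. Nothing at hand gives any reason for this flat result.

From the compounds shown here alone, whether 4-hydroxyphenyl or 3-aminophenyl would stay equally level remains open. So does whether a carboxylic acid on this ring, or a longer chain in its place, would produce a step beyond the scatter.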